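Spiro-azetidine in place of tert-butoxy on the shared core

The source may hold more compounds than are shown below. What is called first, only, known or untested is meant among the compounds shown, and "the series" means these compounds.

Measured compounds:
compound 1, `COc1ccc2[nH]c(C(=O)N3CC(=O)N(Cc4cc5ccccc5[nH]4)[C@@H](Cc4ccccc4)C3)cc2c1`, 11000 nM
compound 2, `COc1ccc2[nH]c(C(=O)N3CC(=O)N(Cc4c[nH]c5ccccc45)[C@@H](Cc4ccccc4)C3)cc2c1`, 10300 nM
compound 3, `COc1ccc2[nH]c(C(=O)N3CC(=O)N(Cc4ccccc4)[C@@H](COC(C)(C)C)C3)cc2c1`, 65500 nM

In a physicochemical assay for solubility, read by spectrophotometry, in phosphate buffer, with a stated time of 2 h, at pH 7.4 (on this read-out higher numbers stand for higher solubility and lower numbers for lower solubility), compound 3 stands highest of the three, well clear of compound 1 and compound 2. Compound 4, `COc1ccc2[nH]c(C(=O)N3CC(=O)N(Cc4ccccc4)[C@@H](CN4CC5(CCC5)C4)C3)cc2c1`, differs from compound 3 by a group of 7 heavy atoms (6 carbon, 1 nitrogen; one four-membered non-aromatic ring of carbon only, one four-membered non-aromatic ring with 1 hetero atom) in place of a group of 5 heavy atoms (4 carbon, 1 oxygen; no ring), on a saturated chain carbon bound to a saturated ring carbon. Among the measured compounds shown here, the only measured step, a 1.1-fold lower number from compound 1 to compound 2 (0.03 log units; within the scatter), concerns a different position and so gives no direct guide to this change; no measured pair touches the saturated chain carbon bound to a saturated ring carbon. The expectation therefore rests on compound 3 alone, and a step of a 2.3-fold higher number from compound 3 to compound 4 (0.36 log units; beyond the scatter) is estimated for compound 4, upward but with wide uncertainty. Compound 4 is thus expected to give about 150000 nM, within 40000 nM to 500000 nM.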

Compound 4, solubility: 60700 nM
Compound 4: the middle estimate sits 2.5-fold (0.39 log units) above what was measured; low and high end bracket the measured number.
By their numbers in this assay, from the lowest: compounds 2 and 1 (each within the scatter of the next); then compounds 4 and 3 (each within the scatter of the next).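

In this assay the exchange of tert-butoxy for the group of 7 heavy atoms, on a saturated chain carbon bound to a saturated ring carbon, gives a 1.1-fold lower number from compound 3 to compound 4 (0.03 log units; within the scatter) and so stays within the scatter. Among the compounds shown here, this is the first measured pair at this place, and it shows that two four-membered rings and a nitrogen can replace the open chain with no difference that can be read. Nothing at hand accounts for this result. The compounds shown leave open how a dimethylamino group or a carboxylic acid would read at this place. They also leave open whether the same exchange would read alike with an indolylmethyl group in place of the benzyl group.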